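The compounds below may be only part of what the source reports. "The series", "measured", "known", "first", "only" and "open" are said of these compounds alone.

Compound 1 `COc1ccc(C(=O)/C=C/c2ccc(OC)c(CC=C(C)C)c2)c(O)c1` and compound 2 `COc1ccc(C(=O)/C=C/c2cccc(CC=C(C)C)c2)c(O)c1` share one core, while compound 3 `COc1ccc2c(c1)OC(c1ccc(OC)c(CC=C(C)C)c1)CC2=O` and the not yet measured compound 4 `COc1ccc(C2CC(=O)c3ccccc3O2)cc1CC=C(C)C` share another; the difference between the two cores is not broken down here. All were tested in an assay on isolated protein for inhibition of Aromatase (Homo sapiens); on this read-out higher numbers stand for weaker inhibition and lower numbers for stronger inhibition. Compound 1 gives > 283000 nM, which is a limit of the assay rather than a number. Compound 2 likewise gives > 310000 nM, again a limit. The change between them, (hydrogen in place of methoxy on an aromatic carbon), therefore produced a step that the two limits leave unreadable from compound 1 to compound 2, and it stays unreadable because compound 1 sits at the limit of > 283000 nM in this assay, at which 1 of the 3 values shown sits, and compound 2 at the limit of > 310000 nM in this assay, at which 1 of the 3 values shown sits. For the measured compounds named here, compound 3 gives 3670 nM, the only number among the three measured. Compound 4 carries the same kind of change, (hydrogen in place of methoxy on an aromatic carbon); here the place is part of a fused or bridged system of two rings, meta to a fused ring and para to a fused ring, whereas in compound 1 it was ortho to a 3-methylbut-2-en-1-yl group and para to a large group. Since the earlier step is unreadable, there is no measured guide to its size. The expected step in this assay is a 1.2-fold higher number from compound 3 to compound 4 (0.09 log units; within the scatter). Compound 4 is thus estimated at 4500 nM, with a likely range from 1200 nM to 18000 nM.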

Compound 4, half-maximal inhibitory concentration: 12100 nM
The estimate for compound 4 lay 2.7-fold (0.43 log units) below the measured number, and the stated range covers the measured number.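

In this assay, putting hydrogen in place of methoxy on the core of compound 3 gives a 3.3-fold higher number from compound 3 to compound 4 (0.52 log units; beyond the scatter), so on this core the change brings a modest but readable weakening of inhibition. The same change cannot be read on the core of compound 1, which means there is no size to set beside that step, since compound 1 gives only a limit of the assay: the limit of > 283000 nM in this assay, at which 1 of the 4 values shown sits. For the compounds shown here, compound 2 also gives only a limit, so the one readable step shows that the change matters on one core and does not show whether its size carries over to the other: the limit of > 310000 nM in this assay, at which 1 of the 4 values shown sits.

The compounds shown compare methoxy only with hydrogen at this place, so it stays open how an ethoxy group or an amine there would read in this assay. Going by these compounds, it also stays open whether the step seen here would hold on any further core.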